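The source may report more compounds than this note shows. Statements on the series, on what has been measured and on what is new or still open speak of the compounds shown alone.

Measured so far in an ADME assay on SH-SY5Y cells (Homo sapiens) for cytotoxicity, read by MTT assay, with a stated time of 72 h; a higher number here means a weaker inhibitor, a lower number a stronger inhibitor:
- compound 1 `O=C(CN1CCN(C(=O)c2ccc(Cl)cc2)CC1)N1CCN(CCCc2c[nH]c3ccccc23)CC1`: 139000 nM
- compound 2 `Cc1ccc(C(=O)N2CCN(CC(=O)N3CCN(CCCc4c[nH]c5ccccc45)CC3)CC2)cc1`: > 200000 nM, a limit
- compound 3 `COc1cccc(C(=O)N2CCN(CC(=O)N3CCN(CCCc4c[nH]c5ccccc45)CC3)CC2)c1`: > 200000 nM, a limit

Compound 1 is the only one of the three with an actual number, so it is the sole numerical anchor in this small set. Compound 4 `COc1ccc2[nH]cc(CCCN3CCN(C(=O)CN4CCN(C(=O)c5ccc(Cl)cc5)CC4)CC3)c2c1` keeps the core of compound 1 and changes one place: methoxy in place of hydrogen on an aromatic carbon. In words, this is methoxy in place of hydrogen on an aromatic carbon, turning 1H-indol-3-yl into 5-methoxy-1H-indol-3-yl.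

The measured steps bear on this only indirectly. They are an at least 1.4-fold higher number from compound 1 to compound 2 (0.15 log units; that floor lies within the scatter) and an at least 1.4-fold higher number from compound 1 to compound 3 (0.15 log units; that floor lies within the scatter), and both alter the aromatic group on the carbonyl, not the group that changes in compound 4. The step that the two limits leave unreadable from compound 2 to compound 3 adds nothing further. Within the data shown here, no measured step therefore sizes this substitution, and no step beyond the scatter is expected in this assay, in either direction. The expectation stays close to compound 1 at 139000 nM. Compound 4 may also be reported only as a limit, given (the limit of > 200000 nM in this assay, at which 2 of the 3 values shown sit).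

The expected change is a 1.0-fold lower number from compound 1 to compound 4 (0.01 log units; within the scatter). For compound 4 the estimated value is 135000 nM, with an expected range of 60000 nM to 200000 nM.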

Compound 4, half-maximal inhibitory concentration: 159000 nM
Beside the measured number, compound 4's estimate is 1.2-fold (0.07 log units) below it, and the stated range covers the measured number.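

In this assay, the change from 1H-indol-3-yl to 5-methoxy-1H-indol-3-yl gives a 1.1-fold higher number from compound 1 to compound 4 (0.06 log units; within the scatter), so on this evidence adding methoxy here leaves the read-out unresolved from the scatter. This is the only step shown at the indole end of the molecule, as the earlier readable steps all concerned the aromatic group on the carbonyl and so gave no size for a change at this place. Compound 4, which keeps the 4-chlorophenyl group of compound 1, also gives an actual number rather than a limit, which separates these two compounds from the rest of the set: the limit of > 200000 nM in this assay, at which 2 of the 4 values shown sit.

What the compounds shown leave open is whether this tolerance belongs to methoxy alone, since a single group at a single place cannot show how hydroxy, fluoro or an amine would read there. As far as these compounds go, it is also open whether the same substitution would stay within the scatter alongside the 4-methylphenyl or 3-methoxyphenyl groups of compound 2 and compound 3, whose values are limits.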